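Swapping one five-membered ring for another beside a sulfonyl

The source may hold more compounds than are shown below. What is called first, only, known or untested is meant among the compounds shown, and "the series" means these compounds.

Measured compounds:
Compound 1 `Cc1ccc(-c2c[nH]nc2S(=O)(=O)CC2=NCCS2)cc1`: "not active" (no number reported)
Compound 2 `COc1ccc(C2=NOC(c3ccc(C)cc3)C2S(=O)(=O)CC2=NCCO2)cc1`: 65.9%
Compound 3 `COc1ccc(C2=NOC(c3ccc(C)cc3)C2S(=O)(=O)CC2=NCCS2)cc1`: 54.1%

All three were tested in a functional assay, read by Griess assay, with a stated time of 150 min, tested at 75 ug/mL; on this read-out higher numbers stand for a stronger effect at the one concentration tested and lower numbers for a weaker effect. Compound 1 was reported without a number. Between compound 3 and compound 2 one change was made: a group of 5 heavy atoms (3 carbon, 1 nitrogen, 1 oxygen; one five-membered non-aromatic ring with 2 hetero atoms) in place of a group of 5 heavy atoms (3 carbon, 1 nitrogen, 1 sulfur; one five-membered non-aromatic ring with 2 hetero atoms), on a saturated chain carbon bound to a sulfonyl sulfur. This brought a number 11.8 percentage points higher from compound 3 to compound 2 (beyond the scatter). Compound 4 `Cc1ccc(-c2c[nH]nc2S(=O)(=O)CC2=NCCO2)cc1` has not yet been tested; it differs from compound 1 by the same change, (a group of 5 heavy atoms (3 carbon, 1 nitrogen, 1 oxygen; one five-membered non-aromatic ring with 2 hetero atoms) in place of a group of 5 heavy atoms (3 carbon, 1 nitrogen, 1 sulfur; one five-membered non-aromatic ring with 2 hetero atoms), on a saturated chain carbon bound to a sulfonyl sulfur), which occurs twice among these compounds. The cores of compound 1 and compound 3 differ, but that difference is not broken down here. Compound 1 shows "not active" (no number reported) in this assay, so a rise like a number 11.8 percentage points higher from compound 3 to compound 2 (beyond the scatter) added to such a base would still leave compound 4 weak. Compound 4 is expected to give about 15% in this assay, estimated between 0% and 35%, and may again be reported as inactive.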

Compound 4, a percentage reported as activity, at one concentration (the size of the read-out at that concentration, not a potency): 63.5%
Compound 4: middle estimate off by 48.5 percentage points, on the low side; measured number outside the range, above it.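

In this assay, within the data shown here, compound 1 is reported as "not active" (no number reported), so no step to compound 4 can be read. These compounds leave open how large the ring swap's effect is on this core. No measurement shown explains the result.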